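Amide-side change on a thiophene-bearing core: expected value

A few compounds are considered here, and "the series" means these few. Any claim that something is new, unique, unknown or untested is made for them only; others in the source may bear on it.

Measured so far:
compound 1 `Nc1c(C(=O)NC2CCCC2)oc2nc(-c3ccccc3)cc(C(F)(F)F)c12` 85000 nM
compound 2 `Cc1ccc(/C=N/NC(=O)c2oc3nc(-c4ccccc4)cc(C(F)(F)F)c3c2N)cc1` 69000 nM
compound 3 `Nc1c(C(=O)NC2CCCC2)oc2nc(-c3cccs3)cc(C(F)(F)F)c12` 51000 nM

All three were run in an ADME assay on HEK293 cells (Homo sapiens) for antiproliferative activity, read by MTT assay; a higher number here means a weaker inhibitor, a lower number a stronger inhibitor. Compound 1 carries the amide nitrogen cyclopentyl; compound 2 differs from it by a group of 9 heavy atoms (8 carbon, 1 nitrogen; one six-membered aromatic ring of carbon only) in place of a group of 5 heavy atoms (5 carbon; one five-membered non-aromatic ring of carbon only), on an amide-type nitrogen, and the step is a 1.2-fold lower number from compound 1 to compound 2 (0.09 log units; within the scatter). Compound 3 differs from compound 1 by thiophen-2-yl in place of phenyl on an aromatic carbon, the step being a 1.7-fold lower number from compound 1 to compound 3 (0.22 log units; within the scatter).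

Compound 4 `Cc1ccc(/C=N/NC(=O)c2oc3nc(-c4cccs4)cc(C(F)(F)F)c3c2N)cc1` is not yet measured in this assay. It differs from compound 3 by a group of 9 heavy atoms (8 carbon, 1 nitrogen; one six-membered aromatic ring of carbon only) in place of a group of 5 heavy atoms (5 carbon; one five-membered non-aromatic ring of carbon only), on an amide-type nitrogen, the same change that leads from compound 1 to compound 2, made on the core of compound 3. The cores of compound 3 and compound 4 differ from those of compound 1 and compound 2 by thiophen-2-yl in place of phenyl on an aromatic carbon.

Going by the values given here, only one earlier instance of this change exists, so the expectation rests on compound 1 and compound 2 alone. The step from compound 3 to compound 4 is expected to be about a 1.2-fold lower number from compound 3 to compound 4 (0.07 log units; within the scatter), because the earlier step was a 1.2-fold lower number from compound 1 to compound 2 (0.09 log units; within the scatter). Compound 4 is therefore estimated at 43000 nM in this assay, with a range of 20000 nM to 95000 nM.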

Compound 4, half-maximal inhibitory concentration: 78000 nM
Estimate against measurement, compound 4: 1.8-fold (0.26 log units) below; the measured number falls inside the stated range.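

In this assay, placing the group of 9 heavy atoms on the amide-type nitrogen in place of cyclopentyl gives a 1.5-fold higher number from compound 3 to compound 4 (0.18 log units; within the scatter), and the two cores do not differ beyond the scatter: the same change on two cores in this assay, a 1.2-fold lower number (0.09 log units; within the scatter) from compound 1 to compound 2 and a 1.5-fold higher number (0.18 log units; within the scatter) from compound 3 to compound 4, 1.9-fold (0.28 log units) apart, within the scatter of two such steps. Placing thiophen-2-yl in place of phenyl gives a 1.1-fold higher number from compound 2 to compound 4 (0.05 log units; within the scatter), and this change also shows no difference between cores beyond the scatter: the same change on two cores in this assay, a 1.7-fold lower number (0.22 log units; within the scatter) from compound 1 to compound 3 and a 1.1-fold higher number (0.05 log units; within the scatter) from compound 2 to compound 4, 1.9-fold (0.28 log units) apart, within the scatter of two such steps. Every step here lies within the scatter, so the agreement shows only that no dependence on the core can be detected, not that an effect of either change carries from one core to another.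

Open, going by these compounds, is whether an amine, a carboxylic acid or a longer chain on the amide-type nitrogen would give a step beyond the scatter in this assay. Also open, on these data alone, is whether such a step would hold on both the core of compound 1 and the core of compound 3.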